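The compounds below may be only part of what the source reports. "The series", "measured", "known", "first", "only" and "open" are said of these compounds alone.

Among the compounds with values here, compound 2, `CN(C)c1ccc(C2CC(c3ccc(-n4cncn4)cc3)=NN2C(=O)CCCl)cc1`, stands lowest of the two numbers so far in a functional assay on MDA-MB-231 cells (Homo sapiens) for inhibition, read by sulforhodamine B assay, tested at 10 uM (on this read-out lower numbers stand for less inhibition and higher numbers for more inhibition at the one concentration tested (going by the name of the read-out)), where compound 2 gives 3.7%. The nearest number belongs to compound 1, `CN(C)c1ccc(C2CC(c3ccc(-n4cncn4)cc3)=NN2)cc1`, which in this assay gives 7%; the step of a number 3.3 percentage points lower from compound 1 to compound 2 (within the scatter) lies within the scatter. Compound 3, `COC(=O)CC(=O)N1N=C(c2ccc(-n3cncn3)cc2)CC1c1ccc(N(C)C)cc1`, differs from compound 2 by methoxycarbonyl in place of chloromethyl on a saturated chain carbon bound to a carbonyl carbon. Within the data shown here, no measured step touches that position on the saturated chain carbon; the one step available, a number 3.3 percentage points lower from compound 1 to compound 2 (within the scatter), concerns the ring nitrogen and was within the scatter, so it bears on the new change only in showing that both measured compounds sit at low inhibition. With nothing pointing in either direction, the expected step from compound 2 to compound 3 is a number 2.3 percentage points higher from compound 2 to compound 3 (within the scatter), none beyond the scatter. Compound 3 is therefore estimated at 6% in this assay, with a range from -6% to 20%.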

Compound 3, a percentage reported as inhibition, at one concentration (the size of the read-out at that concentration, not a potency): 6.8%
Beside the measured number, compound 3's estimate is 0.8 percentage points below it; the range from low to high includes it.
By their numbers in this assay, from the lowest: compounds 2, 3 and 1 (each within the scatter of the next).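

In this assay, methoxycarbonyl in place of chloromethyl on a saturated chain carbon bound to a carbonyl carbon gives a number 3.1 percentage points higher from compound 2 to compound 3 (within the scatter), so the first change measured at this position does not separate the two groups. With ((methoxycarbonyl)methyl)carbonyl in place of hydrogen on an amine nitrogen in a ring, the step is a number 0.2 percentage points lower from compound 1 to compound 3 (within the scatter), so neither of the two groups tested on that nitrogen gives a number outside the scatter of the parent compound. No evidence is available that bears on these values.

As far as these compounds go, whether an amine or a carboxylic acid at this position, or a longer chain, would give a step beyond the scatter remains open. Also open, from the compounds shown here alone, is whether any change to the shared core would raise inhibition clear of these low numbers.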